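Methyl for Chloro on the Anilino Ring

The source may report more compounds than this note shows. Statements on the series, on what has been measured and on what is new or still open speak of the compounds shown alone.

Measured so far:
compound 1 `O=C1C(Nc2ccc(F)cc2)=CC(=O)c2ncncc21`, 0.04 ug/mL
compound 2 `O=C1C(Nc2ccc(Cl)cc2)=CC(=O)c2ncncc21`, 0.01 ug/mL

In a functional assay on XF498 cells (Homo sapiens) for cytotoxicity, read by MTT assay, with a stated time of 72 h (a lower number here means a stronger inhibitor, a higher number a weaker inhibitor), compound 2 holds the lowest of the two numbers; its nearest neighbour is compound 1, and the step of a 4.0-fold lower number from compound 1 to compound 2 (0.60 log units; beyond the scatter) lies beyond the scatter. Compound 3 `Cc1ccc(NC2=CC(=O)c3ncncc3C2=O)cc1` differs from compound 2 by methyl in place of chloro on an aromatic carbon, on an aromatic carbon of a six-membered aromatic ring of carbon only. Only the halogen swap has been measured, and it bears on this change just loosely, so a small step is expected, a 2.0-fold higher number from compound 2 to compound 3 (0.30 log units; within the scatter), toward a slightly higher number. Compound 3 is therefore estimated at 0.02 ug/mL, with a range of 0.007 ug/mL to 0.06 ug/mL.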

Compound 3, half-maximal inhibitory concentration: 0.13 ug/mL
The estimate for compound 3 lay 6.5-fold (0.81 log units) below the measured number; the whole stated range lies below it.
By their numbers in this assay, from the lowest: compound 2; then compound 1; then compound 3.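

In this assay, the swap to methyl gives a 13-fold higher number from compound 2 to compound 3 (1.11 log units; beyond the scatter) and a 3.3-fold higher number from compound 1 to compound 3 (0.51 log units; beyond the scatter), so at this place, para to a large group, methyl stands apart from both halogens. Chloro and methyl each count one heavy atom and neither adds a hydrogen-bond donor or acceptor, so these counts do not separate them. Nothing at hand explains this difference.

Left open is where a methoxy group, an amine or a plain hydrogen would fall at this position. As far as these compounds go, it is also open whether a longer chain would continue the loss seen with methyl.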